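From compound 3 to compound 4 in one ring change

The source may report more compounds than this note shows. Statements on the series, on what has been measured and on what is new or still open speak of the compounds shown alone.

Measured so far in an assay on isolated protein for inhibition of Polyunsaturated fatty acid 5-lipoxygenase (Homo sapiens), read by ELISA; a lower number here means a stronger inhibitor, a higher number a weaker inhibitor:
compound 1, `CC1(C)C=Cc2c(O)cc(/C=C/c3ccc(O)cc3)cc2O1`, gives 2400 nM;
compound 2, `COc1ccc(/C=C/c2c(CC=C(C)C)c(O)cc3c2CCC(C)(C)O3)cc1O`, gives "not active" (no number reported);
compound 3, `CC(C)=CCc1c(O)cc(O)c(CC=C(C)C)c1/C=C/c1ccc(O)cc1`, gives 900 nM.

Compound 3 holds the lowest of the two numbers in this assay. Its nearest neighbour is compound 1, whose number is higher by a gap beyond the usual scatter, while compound 2 carries no number at all. The unmeasured compound 4, `COc1ccc(/C=C/c2c(CC=C(C)C)c(O)cc(O)c2CC=C(C)C)cc1O`, keeps the whole core of compound 3 and differs in one place: 3-hydroxy-4-methoxyphenyl in place of 4-hydroxyphenyl on a double-bonded chain carbon bound to a double-bonded chain carbon.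

Going by the values given here, no pair of measured compounds differing in just this ring exists, so the size of the step is open. Among the compounds with values here, the only compound that already carries the 3-hydroxy-4-methoxyphenyl is compound 2, and in this assay compound 2 gives "not active" (no number reported), though its core also differs from compound 3. On that basis compound 4 is expected to be weaker than compound 3, with a step of a 3.9-fold higher number from compound 3 to compound 4 (0.59 log units; beyond the scatter). Compound 4 is estimated at 3500 nM, in a range from 800 nM to 20000 nM.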

Compound 4, half-maximal inhibitory concentration: 900 nM
For compound 4 the middle estimate is 3.9-fold (0.59 log units) above the measured one; the range from low to high includes it.
By their numbers in this assay, from the lowest: compounds 3 and 4 (each within the scatter of the next); then compound 1.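

In this assay, 3-hydroxy-4-methoxyphenyl in place of 4-hydroxyphenyl on a double-bonded chain carbon bound to a double-bonded chain carbon gives no change at the digits printed from compound 3 to compound 4 (within the scatter). This position on the core of compound 3 therefore accepts the larger ring group with no readable change, and the 3-hydroxy-4-methoxyphenyl, which before stood only on the differing core of compound 2, now stands on a compound with a measured number, so this ring alone does not account for the "not active" of compound 2. Nothing on hand explains why the number holds across this change.

The separate contributions of the hydroxy and the methoxy on the new ring stay open, as the compounds shown carry the two only together. Whether an ethoxy group in place of the methoxy, or an amine in place of the hydroxy, would hold the number also remains an open question.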